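This account rests on a few compounds, and the source may have more. Where it says the series, first, only, none or still open, it means among the compounds named here.

In a functional assay on CCRF-CEM cells (Homo sapiens) for antiproliferative activity, read by fluorescence and resazurin assay, with a stated time of 48 h (on this read-out higher numbers stand for weaker inhibition and lower numbers for stronger inhibition), compound 3 `O=C(N/N=C/c1ccncc1)c1cc2cc([N+](=O)[O-])ccc2oc1=O` gives 13000 nM. Compound 1 `O=C(N/N=C/c1cccnc1)c1cc2ccccc2oc1=O` gives 9900 nM, within the scatter of compound 3, whereas compound 2 `O=C(N/N=C/c1ccncc1)c1cc2cc(Br)ccc2oc1=O` gives 6340 nM. Among the measured compounds shown here, the only measured step confined to one place is a 2.1-fold higher number from compound 2 to compound 3 (0.31 log units; beyond the scatter), a modest step with nitro in place of bromo on an aromatic carbon.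

The next compound is compound 4 `O=C(N/N=C/c1ccncc1)c1cc2ccccc2oc1=O`, which is reached from compound 3 by one change: hydrogen in place of nitro on an aromatic carbon. In words, this is hydrogen in place of nitro on an aromatic carbon. For the measured compounds named here, no measured step shows this exact exchange, so the bromo-to-nitro step bears on it only indirectly, as a guide to how much a change at this carbon has moved the number so far. Compound 1 also carries hydrogen at this carbon but differs from compound 4 elsewhere, and compound 1 with 9900 nM offers the closest reference. Together these suggest a small move towards a lower number, with nothing beyond the scatter expected. The estimate is thus a 1.4-fold lower number from compound 3 to compound 4 (0.16 log units; within the scatter). For compound 4 the expected value is 9000 nM, with an estimated range of 4800 nM to 17000 nM.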

Compound 4, half-maximal inhibitory concentration: 3110 nM
Beside the measured number, compound 4's estimate is 2.9-fold (0.46 log units) above it, and the stated range ends above it.
By their numbers in this assay, from the lowest: compound 4; then compounds 2, 1 and 3 (each within the scatter of the next, the first and the last beyond it).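

Among the compounds shown here, compound 4 is the first compound with hydrogen on this aromatic carbon alongside the pyridin-4-yl group, and in this assay neither substituent improves on hydrogen: the change gives a 4.2-fold lower number from compound 3 to compound 4 (0.62 log units; beyond the scatter) from nitro and a 2.0-fold lower number from compound 2 to compound 4 (0.31 log units; beyond the scatter) from bromo. Together with a 2.1-fold higher number from compound 2 to compound 3 (0.31 log units; beyond the scatter) as the earlier step, this places the three compounds in a clear order at this carbon, with hydrogen lowest, bromo next and nitro highest, each step lying beyond the scatter. For the compounds shown here, the pair with hydrogen at this carbon also shows for the first time that the pyridine attachment matters on its own, since pyridin-4-yl in place of pyridin-3-yl gives a 3.2-fold lower number from compound 1 to compound 4 (0.50 log units; beyond the scatter) and leaves compound 4 with the lowest number of the four. Nothing available explains why either change moves the number as it does.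

On these data alone, only hydrogen, bromo and nitro have been seen at this carbon, so it remains open whether a methoxy group, an amine or a fluorine there would follow the same order. As far as these compounds go, it is also open whether that order holds with pyridin-3-yl at the other end, or how a pyridin-2-yl or plain phenyl ring would compare there.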